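The source may report more compounds than this note shows. Statements on the series, on what has been measured and on what is new or still open speak of the compounds shown alone.

Working notes on the series. Compound 1 `COc1cccc2c1CCC2c1ncc[nH]1`, compound 2 `c1cncc(-c2cccc3c2CCC3c2ncc[nH]2)c1` and compound 3 `CNC(=O)c1cccc2c1CCC2c1ncc[nH]1` share one core and differ only in the group carried on one aromatic carbon. In a functional assay on CHO cells for agonist activity at Alpha-1D adrenergic receptor (Homo sapiens), read by FLIPR and calcium flux (on this read-out higher numbers stand for an effect only at larger amounts of compound and lower numbers for an effect already at smaller amounts), compound 1 gives > 10000 nM, which is a limit of the assay and not a number. In this assay compound 2 gives > 10000 nM, again a limit. In this assay compound 3 gives > 10000 nM, also a limit. All three values sit at the limit of > 10000 nM in this assay, at which 3 of the 3 values shown sit, so the steps a step that the two limits leave unreadable from compound 1 to compound 2, a step that the two limits leave unreadable from compound 1 to compound 3 and a step that the two limits leave unreadable from compound 2 to compound 3 cannot be read in size, and compound 3 stands on the numbers shown at the same limit as the other two, without ranking among them.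

Compound 4 `c1cc(-c2nccs2)c2c(c1)C(c1ncc[nH]1)CC2` is not yet measured. It differs from compound 3 by 1,3-thiazol-2-yl in place of methylcarbamoyl on an aromatic carbon. Within the data shown here, none of the measured steps bears on this change with a readable size; every exchange of the group at this position has so far given only a limit. On that basis the expected step is a step that the limit leaves unreadable from compound 3 to compound 4, with no movement beyond the scatter in either direction. Compound 4 is estimated at 15000 nM, with a range from 5000 nM to 50000 nM, most likely reported as a limit again.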

Compound 4, half-maximal effective concentration: 3190 nM
Beside the measured number, compound 4's estimate is 4.7-fold (0.67 log units) above it; measured number outside the range, below it.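

In this assay, 1,3-thiazol-2-yl in place of methylcarbamoyl gives an at least 3.1-fold lower number from compound 3 to compound 4 (0.49 log units; beyond the scatter), in place of pyridin-3-yl it gives an at least 3.1-fold lower number from compound 2 to compound 4 (0.49 log units; beyond the scatter), and in place of methoxy it gives an at least 3.1-fold lower number from compound 1 to compound 4 (0.49 log units; beyond the scatter). The earlier steps shown here could not be read in size, so only now does the group on this aromatic carbon show a readable effect on the read-out, and all three new steps are lower bounds on the true size. Compound 4 is the only compound of the four with a number rather than a limit: the limit of > 10000 nM in this assay, at which 3 of the 4 values shown sit.

Open, as far as these compounds go, is whether this shift belongs to 1,3-thiazol-2-yl alone or extends to another five-membered aromatic ring with 2 hetero atoms. Also open, from the compounds shown here alone, is how an amine or a carboxylic acid on this carbon would read.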